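Dibromomethyl for methyl on the lactone core

A few compounds are considered here, and "the series" means these few. Any claim that something is new, unique, unknown or untested is made for them only; others in the source may bear on it.

Measured compounds:
compound 1, `CCC[C@@H](OC(C)=O)C1=C(Br)[C@@](C)(OC)OC1=O`: > 20 ug/mL
compound 2, `CCC[C@@H](O)C1=C(Br)/C(=C/Br)OC1=O`: 0.3 ug/mL

In a functional assay on Lu1 cells (Homo sapiens) for cytotoxicity (a lower number here means that less compound is needed, a higher number that more compound is needed for the effect), compound 1 gives only a limit, > 20 ug/mL, so no number is known for it. Compound 1 therefore sits at the limit of > 20 ug/mL in this assay, at which 1 of the 2 values shown sits, and its place among the measured values is fixed only as a boundary. Within the data shown here, for compound 2 the same assay gives 0.3 ug/mL, a true number; the two compounds share little beyond the lactone, and no step between them is worked out here.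

Compound 3, `CCC[C@@H](OC(C)=O)C1=C(Br)[C@](OC)(C(Br)Br)OC1=O`, is not yet measured in this assay. It differs from compound 1 in one place: dibromomethyl in place of methyl on a saturated ring carbon. Since compound 1 is known only as a limit, the size of the step cannot be read from a measured pair, so the expectation rests on the change itself and on the numbers shown. A move toward lower values is expected, beyond the usual scatter but not large; compound 3 is estimated at 8 ug/mL, within 2 ug/mL to 30 ug/mL, which is the step of an at least 2.5-fold lower number from compound 1 to compound 3 (0.39 log units; beyond the scatter) expected from this estimate.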

Compound 3, concentration for half-maximal effect: > 20 ug/mL
Compound 3 gave a limit, no number (the forecaster's own chance of this, stated with the estimate: 40%); at least 2.5-fold (0.39 log units) between middle value and limit.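

In this assay compound 3 gives > 20 ug/mL, which is a limit and not a number. Compound 1 is also known only as a limit, so no step can be read between compound 1 and compound 3. The compounds shown leave open whether dibromomethyl in place of methyl changes the value at all: the limit of > 20 ug/mL in this assay, at which 2 of the 3 values shown sit.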